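The source may report more compounds than this note shows. Statements on the series, on what has been measured and on what is new or still open speak of the compounds shown alone.

Measured in a functional assay on Bel-7402 cells (Homo sapiens) for inhibition, read by MTT assay, with a stated time of 24 h, tested at 1 ug/mL; a lower number here means less inhibition of growth, a higher number more inhibition of growth at the concentration tested:
- Compound 1 `O=C(CCCCC1CCSS1)Nc1ccc(OC(F)(F)F)cc1`: 0.29%
- Compound 2 `O=C(CCCCC(S)CCS)Nc1ccc(OC(F)(F)F)cc1`: 7.32%

Going by the values given here, compound 2, at 7.32%, stands level within the scatter with compound 1, the only other compound measured. Both numbers mean little inhibition of growth at the concentration tested.

Compound 3 `O=C(CCCCC(S)CCS)Nc1ccc([N+](=O)[O-])cc1` keeps the open chain of compound 2 but swaps a group on the aromatic ring: nitro in place of trifluoromethoxy on an aromatic carbon. This puts nitro in place of trifluoromethoxy on an aromatic carbon.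

Among the compounds with values here, the only measured step, a number 7 percentage points higher from compound 1 to compound 2 (within the scatter), was a change in the chain, so it bears only loosely on this swap. Within the data shown here, no measured compound carries nitro, so the data favour no direction. The expected step of a number 0.7 percentage points higher from compound 2 to compound 3 (within the scatter) stays within the scatter. For compound 3 the estimate is 8%, with an expected range of 0% to 20%.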

Compound 3, percent growth inhibition at one concentration: 1.73%
Beside the measured number, compound 3's estimate is 6.3 percentage points above it; the range from low to high includes it.
By their numbers in this assay, from the lowest: compounds 1, 3 and 2 (each within the scatter of the next).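

Going by these compounds alone, compound 3 gives the first look at a change on the aromatic ring rather than in the chain: with nitro in place of trifluoromethoxy, on an aromatic carbon para to a large group, the reading in this assay is a number 5.6 percentage points lower from compound 2 to compound 3 (within the scatter). This swap therefore does not separate compound 3 from compound 2, and inhibition of growth at the concentration tested stays small in all three compounds. Nothing measured here speaks to the reason for this reading.

As far as these compounds go, whether any group at this position can lift the number clear of the scatter stays open, and an amine or a carboxylic acid in place of nitro would test that. Also open, from the compounds shown here alone, is whether the same swap would read alike on the closed ring of compound 1.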